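The source may report more compounds than this note shows. Statements on the series, on what has been measured and on what is new or still open speak of the compounds shown alone.

Measured so far:
compound 1 `CC1(C)CN(NC(=S)Nc2cccc(C#N)c2)c2cc(Cl)ccc2O1` — in a functional assay on thoracic aorta (Rattus norvegicus) (a higher number here means that more compound is needed for the effect, a lower number that less compound is needed), compound 1 gives > 30000 nM, which is a limit of the assay.
compound 2 `CC1(C)CN(NC(=S)Nc2ccc(C#N)cc2)c2cc(Cl)ccc2O1` — in this assay compound 2 gives > 30000 nM, also a limit of the assay.

Compound 2 stands only at a limit, not at a number, and compound 1 sits at the same limit (the limit of > 30000 nM in this assay, at which 2 of the 2 values shown sit). Going by the values given here, the only measured step, a step that the two limits leave unreadable from compound 1 to compound 2, has no readable size: both of its ends are limits. Compound 3 `CC1(C)CN(NC(=S)Nc2cccc(Cl)c2)c2cc(Cl)ccc2O1` differs from compound 2 by 3-chlorophenyl in place of 4-cyanophenyl on an amide-type nitrogen. Among the compounds with values here, no measured step shares this change, so the data give neither a size nor a direction for it. With compound 2 at a limit in this assay, compound 3 is expected to stay near that limit, and the step of a number no higher from compound 2 to compound 3 (the limit leaves the size open) is an estimate of no change beyond the scatter. Compound 3 is therefore expected to give about 30000 nM in this assay, within 8000 nM to 100000 nM.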

Compound 3, half-maximal effective concentration: > 30000 nM
Compound 3: a limit, no number (the forecaster's own chance of this, stated with the estimate: 75%); the middle value sits exactly at the limit.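

Going by these compounds alone, no step between compound 1, compound 2 and compound 3 can be read, because each value is a limit of the assay and not a number: the limit of > 30000 nM in this assay, at which 3 of the 3 values shown sit. The compounds shown leave open what number each compound would reach, and whether these changes on the phenyl ring alter the concentration needed at all.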